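This account rests on a few compounds, and the source may have more. Where it says the series, first, only, none or still open, it means among the compounds named here.

Measured so far, in an ADME assay on WI-38 cells (Homo sapiens) for antiproliferative activity, read by MTT assay, with a stated time of 72 h; on this read-out higher numbers stand for weaker inhibition and lower numbers for stronger inhibition:
compound 1 `CCCCCCc1cc2cn(Cc3cn(Cc4ccccc4)nn3)c(=O)nc2o1` gives 62800 nM;
compound 2 `O=c1nc2oc(C3CC3)cc2cn1Cc1cn(Cc2ccccc2)nn1` gives 29700 nM.

Compound 2 stands at the lowest of these two numbers, so it is the stronger inhibitor of the pair. Going by the values given here, the only measured step, a 2.1-fold lower number from compound 1 to compound 2 (0.33 log units; beyond the scatter), came from putting cyclopropyl in place of hexyl on an aromatic carbon.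

Compound 3 `O=c1nc2oc(CCCCl)cc2cn1Cc1cn(Cc2ccccc2)nn1` has not been measured in this assay. It differs from compound 2 in one place: 3-chloropropyl in place of cyclopropyl on an aromatic carbon. Among the compounds with values here, the single step measured bears on this change only loosely, since it moved from hexyl to cyclopropyl, and the present change leaves cyclopropyl for 3-chloropropyl, which is again a group without a ring. Because a 2.1-fold lower number from compound 1 to compound 2 (0.33 log units; beyond the scatter) was modest, compound 3 is expected to move back toward compound 1, by a small step, a 1.4-fold higher number from compound 2 to compound 3 (0.15 log units; within the scatter), that may not exceed the scatter. The estimate for compound 3 in this assay is 42000 nM, with a range from 15000 nM to 110000 nM.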

Compound 3, half-maximal inhibitory concentration: 5200 nM
Compound 3: the middle estimate sits 8.1-fold (0.91 log units) above what was measured; measured number outside the range, below it.
By their numbers in this assay, from the lowest: compound 3; then compound 2; then compound 1.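

In this assay, the aromatic carbon next to the ring oxygen responds to more than whether the group there has a ring: 3-chloropropyl in place of cyclopropyl gave a 5.7-fold lower number from compound 2 to compound 3 (0.76 log units; beyond the scatter), so a chain without a ring can give stronger inhibition here than a ring does. Chains also differ sharply from one another, with a 12-fold lower number from compound 1 to compound 3 (1.08 log units; beyond the scatter) for chloro in place of propyl on a saturated chain carbon, three bonds along the chain from an aromatic carbon, a larger step than the one from hexyl to cyclopropyl. Nothing available explains why compound 3 gives the lowest number of the three. Still open, as far as these compounds go, is whether the chlorine itself accounts for this drop, a question that a plain propyl chain, or a propyl chain ending in an amine or a hydroxyl, would address at this position.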